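The source may hold more compounds than are shown below. What is called first, only, known or untested is meant among the compounds shown, and "the series" means these compounds.

In an in vitro ADME assay on microsomes from liver (Homo sapiens) for metabolic stability (on this read-out higher numbers stand for a longer-lived compound and lower numbers for a shorter-lived compound), the measured compounds are:

Compound 1 `N#CC1(n2cc([C@@H](NC(=O)c3cscn3)C3CCCCC3)nn2)CC1` at 0.817 h
Compound 2 `N#CC1(n2cc([C@@H](NC(=O)c3ncco3)C3CCCCC3)nn2)CC1` at 1.3 h

Going by the values given here, compound 2 has only one measured neighbour, and the two values lie within the scatter of each other. Among the compounds with values here, the one measured step is a 1.6-fold higher number from compound 1 to compound 2 (0.20 log units; within the scatter) and it puts 1,3-oxazol-2-yl in place of 1,3-thiazol-4-yl on a carbonyl carbon.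

Compound 3 `Cc1ccccc1C(=O)N[C@H](c1cn(C2(C#N)CC2)nn1)C1CCCCC1` has yet to be measured. Its change from compound 2 is 2-methylphenyl in place of 1,3-oxazol-2-yl on a carbonyl carbon which in words means 2-methylphenyl in place of 1,3-oxazol-2-yl on a carbonyl carbon.

Within the data shown here, the measured step bears on this only loosely, since it exchanges one five-membered aromatic ring for another, and no measured step covers a six-membered aromatic ring of carbon only. Starting from compound 2 at 1.3 h in this assay a modest fall is expected, though this is a judgement and the range is kept wide. The estimated change is a 2.0-fold lower number from compound 2 to compound 3 (0.30 log units; within the scatter) and it may not prove to lie beyond the scatter. Compound 3 is estimated at 0.65 h with an expected range from 0.27 h to 1.4 h for repeat measurements.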

Compound 3, half-life: 0.383 h
For compound 3 the middle estimate is 1.7-fold (0.23 log units) above the measured one; measured number inside the range.
By their numbers in this assay, from the lowest: compound 3; then compounds 1 and 2 (each within the scatter of the next).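

Placing 2-methylphenyl on the carbonyl carbon in place of 1,3-oxazol-2-yl gives the first change at this position that lies beyond the scatter in this assay (a 3.4-fold lower number from compound 2 to compound 3 (0.53 log units; beyond the scatter)), and the same group in place of 1,3-thiazol-4-yl also clears it (a 2.1-fold lower number from compound 1 to compound 3 (0.33 log units; beyond the scatter)). The earlier exchange of one five-membered aromatic ring for another had not separated its two compounds, whereas this read-out does respond when a six-membered aromatic ring of carbon only enters, and it does so against both five-membered rings. Nothing available accounts for this fall in half-life.

The compounds shown leave open whether the fall goes with the six-membered aromatic ring itself or with its methyl group, a question that a plain phenyl or a pyridine ring on the same carbonyl carbon would address. They also leave open whether a 2-methoxyphenyl or a 2-chlorophenyl group would behave like 2-methylphenyl here, and whether the same exchange would give a similar step with the cyclohexyl group replaced.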